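From compound 3 to the chlorinated compound 4

The compounds below may be only part of what the source reports. "The series", "measured", "known", "first", "only" and "open" are said of these compounds alone.

In a functional assay on the whole organism for antagonist activity, with Rattus norvegicus as the target (on this read-out higher numbers stand for an effect only at larger amounts of compound and lower numbers for an effect already at smaller amounts), compound 1 `c1ccc2c(c1)CC2CCCN1CCN(c2cccc3c2OCCO3)CC1` gives 0.18 mg/kg, compound 2 `c1ccc2c(c1)CCC2CCCN1CCN(c2cccc3c2OCCO3)CC1` gives 0.29 mg/kg and compound 3 `c1ccc2c(c1)CC(CCCN1CCN(c3cccc4c3OCCO4)CC1)C2` gives 0.47 mg/kg. Compound 3 is clearly separated from only one of the other two: the measured steps are a 2.6-fold higher number from compound 1 to compound 3 (0.42 log units; beyond the scatter) and a 1.6-fold higher number from compound 2 to compound 3 (0.21 log units; within the scatter).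

Compound 4 `Clc1cccc2c1CC2CCCN1CCN(c2cccc3c2OCCO3)CC1` brings the next change, (a group of 9 heavy atoms (8 carbon, 1 chlorine; one four-membered non-aromatic ring of carbon only, one six-membered aromatic ring of carbon only) in place of a group of 9 heavy atoms (9 carbon; one five-membered non-aromatic ring of carbon only, one six-membered aromatic ring of carbon only), on a saturated chain carbon, three bonds along the chain from an amine nitrogen in a ring). This restores the four-membered non-aromatic ring of compound 1 and adds chlorine. The closest guide is a 2.6-fold higher number from compound 1 to compound 3 (0.42 log units; beyond the scatter), read backwards, as it covers the same change of ring. The other ring comparison, a 1.6-fold higher number from compound 1 to compound 2 (0.21 log units; within the scatter), stays within the scatter and points the same way. Within the data shown here, no measured compound carries chlorine, so that part of the change has no measured step behind it, and the range is kept wide.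

A modest fall in the number is therefore expected, towards compound 1 at 0.18 mg/kg. The expected step runs a 2.1-fold lower number from compound 3 to compound 4 (0.33 log units; beyond the scatter). For compound 4 the estimate is 0.22 mg/kg, with an expected range of 0.09 mg/kg to 0.55 mg/kg.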

Compound 4, dose for 50% inhibition: 3.09 mg/kg
Compound 4: middle estimate off by 14-fold (1.15 log units), on the low side; measured number outside the range, above it.
By their numbers in this assay, from the lowest: compounds 1, 2 and 3 (each within the scatter of the next, the first and the last beyond it); then compound 4.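

In this assay chloro in place of hydrogen on an aromatic carbon is the only difference behind a 17-fold higher number from compound 1 to compound 4 (1.23 log units; beyond the scatter), so a single substitution on the core of compound 1 outweighs every ring change among the unchlorinated compounds. The chlorinated four-membered ring group also stands clear of both indenyl groups at the saturated chain carbon, with an 11-fold higher number from compound 2 to compound 4 (1.03 log units; beyond the scatter) and a 6.6-fold higher number from compound 3 to compound 4 (0.82 log units; beyond the scatter), which reverses the place that the unchlorinated four-membered ring of compound 1 held as the lowest number of the series. Nothing measured here accounts for the size of this step.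

As far as these compounds go, whether fluoro or methyl on the same aromatic carbon would give a step of similar size remains open. So does the effect of chloro on the aromatic ring of the 2,3-dihydro-1H-inden-1-yl or 2,3-dihydro-1H-inden-2-yl groups.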